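Cyano for amino on the pendant phenyl ring

This account rests on a few compounds, and the source may have more. Where it says the series, first, only, none or still open, it means among the compounds named here.

The shared core of compound 1 `COc1ccc(S(=O)(=O)N2CCc3cccc(-c4ccc(N)cc4)c32)cc1` carries a 4-aminophenyl group, and in a functional assay on NCI-H460 cells (Homo sapiens) for inhibition, with a stated time of 72 h (on this read-out higher numbers stand for weaker inhibition and lower numbers for stronger inhibition), compound 1 gives 288 nM, the second highest of the three numbers recorded. Compound 2 `COc1ccc(S(=O)(=O)N2CCc3cccc(-c4ccc(F)nc4)c32)cc1`, with 6-fluoropyridin-3-yl in place of 4-aminophenyl, gives 135 nM, a step of a 2.1-fold lower number from compound 1 to compound 2 (0.33 log units; beyond the scatter). Compound 3 `COc1ccc(S(=O)(=O)N2CCc3cccc(-c4ccc(N(C)C)cc4)c32)cc1`, with dimethylamino in place of amino, gives 556 nM, a step of a 1.9-fold higher number from compound 1 to compound 3 (0.29 log units; within the scatter). Compound 4 `COc1ccc(S(=O)(=O)N2CCc3cccc(-c4ccc(C#N)cc4)c32)cc1` has not yet been measured; it differs from compound 1 as follows: cyano in place of amino on an aromatic carbon. The step to compound 3 shows that altering the amino group itself leaves the number within the scatter, while the step to compound 2 shows that replacing the group with one that is an acceptor only brings a modest improvement. Taking both together, compound 4 is expected to show a step of a 1.4-fold lower number from compound 1 to compound 4 (0.16 log units; within the scatter), which is no more than modest and may fall within the scatter. Compound 4 is therefore estimated at 200 nM, with a range from 90 nM to 450 nM.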

Compound 4, half-maximal inhibitory concentration: 29.5 nM
Estimate against measurement, compound 4: 6.8-fold (0.83 log units) above; measured number outside the range, below it.
By their numbers in this assay, from the lowest: compound 4; then compound 2; then compounds 1 and 3 (each within the scatter of the next).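

In this assay the cyano group on the pendant phenyl ring gives a 9.8-fold lower number from compound 1 to compound 4 (0.99 log units; beyond the scatter) and so shows that this place, para to a large group, can respond far more strongly to a change of group than the amino and dimethylamino pair had indicated. Against the other two groups the same cyano group gives a 19-fold lower number from compound 3 to compound 4 (1.28 log units; beyond the scatter) and a 4.6-fold lower number from compound 2 to compound 4 (0.66 log units; beyond the scatter) and thus places compound 4 lowest of the four, beyond the scatter of each of the others. Nothing available explains the size of these steps.

From the compounds shown here alone, whether the lower number is particular to the cyano group or also appears with a trifluoromethyl group, a carboxylic acid or a primary amide at this place stays open. Also open, going by these compounds, is whether a cyano group in place of the fluorine of compound 2 would give a similar number.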